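A benzyl group enters the amide series

The compounds below may be only part of what the source reports. "The series", "measured", "known", "first", "only" and "open" are said of these compounds alone.

compound 1 `CCn1cc(C(=O)Nc2ccccc2O)c(=O)c2cc(F)c(N3CCNC(C)C3)c(F)c21` gives 7430 nM here
compound 2 `CCn1cc(C(=O)Nc2ccc(Cl)cn2)c(=O)c2cc(F)c(N3CCNC(C)C3)c(F)c21` gives 4800 nM here
compound 3 `CCn1cc(C(=O)Nc2ccc(C)c([N+](=O)[O-])c2)c(=O)c2cc(F)c(N3CCNC(C)C3)c(F)c21` gives 4200 nM here

These three values come from a functional assay on MDA-MB-231 cells (Homo sapiens) for cytotoxicity, read by MTT assay (a higher number here means a weaker inhibitor, a lower number a stronger inhibitor), and none separates from the others. Compound 3 at 4200 nM stands level with both other compounds. The steps run a 1.8-fold lower number from compound 1 to compound 3 (0.25 log units; within the scatter) and a 1.1-fold lower number from compound 2 to compound 3 (0.06 log units; within the scatter) and a 1.5-fold lower number from compound 1 to compound 2 (0.19 log units; within the scatter) with each of them inside the scatter.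

Compound 4 `CCn1cc(C(=O)NCc2ccc(OC)cc2)c(=O)c2cc(F)c(N3CCNC(C)C3)c(F)c21` has not yet been measured. It carries 4-methoxybenzyl in place of 4-methyl-3-nitrophenyl on an amide-type nitrogen. The difference 4-methoxybenzyl in place of 4-methyl-3-nitrophenyl on an amide-type nitrogen is the whole change from compound 3.

Going by the values given here, all three measured steps swap the group on this same nitrogen, so they bear on the change, yet no measured compound has a benzyl group. No step beyond the scatter is therefore expected in this assay and no direction is favoured. The expected outcome is a 1.2-fold higher number from compound 3 to compound 4 (0.08 log units; within the scatter) on this estimate. Compound 4 is estimated at 5000 nM with an expected range from 2200 nM to 11000 nM for now.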

Compound 4, half-maximal inhibitory concentration: 25300 nM
Estimate against measurement, compound 4: 5.1-fold (0.70 log units) below; measured number above the stated range.
By their numbers in this assay, from the lowest: compounds 3, 2 and 1 (each within the scatter of the next); then compound 4.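

In this assay the amide-type nitrogen had shown no separation among three ring groups, but 4-methoxybenzyl brings the first change beyond the scatter at this position: the number rises in every comparison, modestly in each case (a 6.0-fold higher number from compound 3 to compound 4 (0.78 log units; beyond the scatter); a 5.3-fold higher number from compound 2 to compound 4 (0.72 log units; beyond the scatter); a 3.4-fold higher number from compound 1 to compound 4 (0.53 log units; beyond the scatter)). Going by these compounds alone, compound 4 is therefore the weakest of the four, and the only one with a benzyl group on this nitrogen. Nothing available explains why this change weakens the compound.

The compounds shown cannot separate the benzyl group from its methoxy substituent, since compound 4 is the only one to carry either. An unsubstituted benzyl or a 4-methoxyphenyl group on the same nitrogen would pull these two features apart.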